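Swapping Bromine for a Carboxylic Acid on the Ketone Ring

The source may report more compounds than this note shows. Statements on the series, on what has been measured and on what is new or still open speak of the compounds shown alone.

Measured compounds:
Compound 1, `O=C(/C(=C\c1ccc([N+](=O)[O-])c(O)c1)SCc1ccc(Br)cc1)c1ccc(Br)cc1`: 10000 nM
Compound 2, `O=C(/C(=C\c1ccc([N+](=O)[O-])c(O)c1)Sc1c(F)c(F)c(F)c(F)c1F)c1ccc(Br)cc1`: 10000 nM

For the measured compounds named here, only two compounds have been measured so far, and both sit at the same level. In a functional assay on DU-145 cells (Homo sapiens) for inhibition, read by trypan blue exclusion, with a stated time of 96 h (on this read-out lower numbers stand for stronger inhibition of growth and higher numbers for weaker inhibition of growth), compound 1 gives 10000 nM. Compound 2, which carries a different group on the sulfur, gives 10000 nM, and the step of no change at the digits printed from compound 1 to compound 2 (within the scatter) falls within the scatter of repeated measurements. Compound 1 therefore stands level with compound 2; neither can be called more or less active than the other.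

Compound 3, `O=C(O)c1ccc(C(=O)/C(=C\c2ccc([N+](=O)[O-])c(O)c2)SCc2ccc(Br)cc2)cc1`, differs from compound 1 by carboxy in place of bromo on an aromatic carbon. Going by the values given here, the single measured step, no change at the digits printed from compound 1 to compound 2 (within the scatter), concerns the group on the sulfur rather than the ring carrying the bromine, so no measured step bears directly on this change, and the two measured values give no sign that any change to the shared core moves this read-out. I therefore expect no step beyond the scatter, no change at the digits printed from compound 1 to compound 3 (within the scatter). For compound 3 the estimate in this assay is 10000 nM, with a range from 5000 nM to 20000 nM.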

Compound 3, concentration for 50% growth inhibition: 10000 nM
Compound 3: middle estimate and measured number agree at the digits printed; the range from low to high includes it.
By their numbers in this assay, from the lowest: compounds 1, 2 and 3 (each within the scatter of the next).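

In this assay, for the compounds shown here, the step of no change at the digits printed from compound 1 to compound 3 (within the scatter) gives the first measured look at the aromatic ring that carries the bromo group, whereas the earlier pair of compounds spoke only to the group on the sulfur. At this position, 4-carboxyphenyl reads level with 4-bromophenyl, even though the carboxy group brings more heavy atoms and a hydrogen-bond donor and acceptor that bromo lacks. Nothing measured here offers an explanation for why these two groups read alike.

With all three compounds at the same printed number, the set does not show whether any change at this position, or on the sulfur, can move this read-out at all. Going by these compounds alone, it remains open whether an amine or a methyl ester in place of the bromo group, or a longer chain on the sulfur, would give a different number from the one shared by compounds 1, 2 and 3.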